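Compound 3 to Compound 4: Ring Exchange on the Sulfonyl Sulfur

The source may hold more compounds than are shown below. What is called first, only, known or untested is meant among the compounds shown, and "the series" means these compounds.

The three measured compounds share one core and differ only in the group on the sulfonyl sulfur. Compound 1 `CSc1ccc(S(=O)(=O)NC(=O)Nc2ccc(Cl)cc2)s1` gives 29% in a functional assay on the whole organism (6C3HED cells, Mus musculus) for inhibition, at a dose of 150 mg/kg by the oral route; a lower number here means less inhibition, a higher number more inhibition at the dose given (going by the name of the read-out). Compound 2 `CCc1ccc(S(=O)(=O)NC(=O)Nc2ccc(Cl)cc2)s1` gives 57%, and compound 3 `CCc1ccc(S(=O)(=O)NC(=O)Nc2ccc(Cl)cc2)o1` gives 57%. Compound 3 thus stands level with compound 2, and these two together hold the highest numbers of the three; compound 1 lies furthest away, as the step of a number 28 percentage points higher from compound 1 to compound 3 (beyond the scatter) shows. The exchange of rings, no change at the digits printed from compound 2 to compound 3 (within the scatter), passed without a shift in the read-out, whereas the exchange of chains, a number 28 percentage points higher from compound 1 to compound 2 (beyond the scatter), brought a modest rise.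

Compound 4 `CCc1ccsc1S(=O)(=O)NC(=O)Nc1ccc(Cl)cc1` is the compound yet to be measured. It differs from compound 3 in one place: 3-ethylthiophen-2-yl in place of 5-ethylfuran-2-yl on a sulfonyl sulfur. The step from compound 2 to compound 3 bears most directly on this, as it also replaced a 5-ethylfuran-2-yl with a 5-ethylthiophen-2-yl and left the read-out unchanged. Within the data shown here, no measured pair, however, exchanges a 5-ethyl ring for a 3-ethyl ring, so that part of the change is untested. Compound 4 is therefore expected to sit close to compound 3, with an estimated step of a number 5 percentage points lower from compound 3 to compound 4 (within the scatter) within the scatter, though the range is kept wide. The estimate for compound 4 in this assay is 52%, between 28% and 76%.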

Compound 4, a percentage reported as inhibition, in the whole organism at one dose (the size of the read-out at that dose, not a potency): 21%
The estimate for compound 4 lay 31 percentage points above the measured number, and the stated range ends above it.
By their numbers in this assay, from the lowest: compounds 4 and 1 (each within the scatter of the next); then compounds 2 and 3 (each within the scatter of the next).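

In this assay, among these compounds, the step of a number 36 percentage points lower from compound 2 to compound 4 (beyond the scatter) shows what the earlier compounds could not: on a sulfonyl sulfur, the read-out depends on where the ethyl sits on the ring, as 5-ethylthiophen-2-yl and 3-ethylthiophen-2-yl differ only in that respect. The step of a number 36 percentage points lower from compound 3 to compound 4 (beyond the scatter) is of the same size, and since the exchange of rings alone gave no change at the digits printed from compound 2 to compound 3 (within the scatter) the loss in this pair goes with the changed place of the ethyl and not with the exchange of oxygen for sulfur in the ring. The step of a number 8 percentage points lower from compound 1 to compound 4 (within the scatter) then shows that an ethyl does not by itself secure the higher read-out, for 3-ethylthiophen-2-yl stands within the scatter of 5-(methylsulfanyl)thiophen-2-yl.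

Nothing available here gives a reason for this loss. The compounds shown leave open whether 3-ethylfuran-2-yl would follow the thiophene pair, and whether a 3-methylthiophen-2-yl or a 3-propylthiophen-2-yl group would read the same as 3-ethylthiophen-2-yl.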